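This account rests on a few compounds, and the source may have more. Where it says the series, first, only, none or still open, it means among the compounds named here.

Of the compounds shown here, three have been tested in an ADME assay on HeLa cells (Homo sapiens) for cytotoxicity, read by MTT assay, with a stated time of 2 days; on this read-out lower numbers stand for higher toxicity in this test and higher numbers for lower toxicity in this test. Compound 1, with structure `CNC(=O)c1cc(Oc2ccc3cc(C(=O)OC(C)C)sc3c2)ccn1`, gives 45000 nM in this assay. Compound 2, with structure `CNC(=O)c1cc(Oc2ccc3c(C)c(C(=O)OC(C)C)sc3c2)ccn1`, gives 9600 nM. The change between them is methyl in place of hydrogen on an aromatic carbon, and in this assay it gave a 4.7-fold lower number from compound 1 to compound 2 (0.67 log units; beyond the scatter). Compound 3, with structure `CCOC(=O)c1cc2ccc(OC)cc2s1`, gives 44400 nM; the difference between its core and the core of compound 1 is not broken down here.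

Compound 4, with structure `CCOC(=O)c1sc2cc(OC)ccc2c1C`, has not yet been measured in this assay. It differs from compound 3 by methyl in place of hydrogen on an aromatic carbon. This is the same kind of change as that from compound 1 to compound 2, made at a place that differs in one respect: there the methyl sits next to the ring atom that bears an isopropoxycarbonyl group, here next to the ring atom that bears an ethoxycarbonyl group.

If the change behaves as it did from compound 1 to compound 2, compound 4 is expected to show a 4.4-fold lower number from compound 3 to compound 4 (0.65 log units; beyond the scatter) in this assay, since compound 3 gives 44400 nM. The estimate for compound 4 is therefore 10000 nM, between 4000 nM and 30000 nM.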

Compound 4, half-maximal cytotoxic concentration: > 100000 nM
Compound 4 ended at the assay's limit; the forecaster's own chance of this, stated with the estimate: 10%; middle value at least 10-fold (1.00 log units) away from the limit.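

On the core of compound 3, the same methyl change gave an at least 2.2-fold higher number from compound 3 to compound 4 (0.35 log units; beyond the scatter) in this assay. This runs in the opposite direction to the earlier step, so in these two pairs the change does not carry over from one core to the other: the same change on two cores in this assay, a 4.7-fold lower number (0.67 log units; beyond the scatter) from compound 1 to compound 2 and an at least 2.2-fold higher number (0.35 log units; beyond the scatter) from compound 3 to compound 4, at least 10-fold (1.02 log units) apart, beyond the scatter of two such steps
Compound 4 gives > 100000 nM, which is a limit of the assay and not a number, so the direction of its step is known but not its full size: the limit of > 100000 nM in this assay, at which 1 of the 4 values shown sits.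

Within the data shown here, with only two pairs, this does not show which difference between the cores goes with the reversal, nor does it give a rule for other cores. The compounds shown leave open whether the ethoxycarbonyl or the isopropoxycarbonyl group plays any part, since no pair changes that group alone. They also leave open how an ethyl group in place of the methyl, or a carboxylic acid in place of the ester, would read in this assay.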